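The compounds below may be only part of what the source reports. "The series", "measured", "known", "first", "only" and "open" are said of these compounds alone.

Compound 1 `NC(=O)c1c[nH]c([C@@H](O)c2ccccc2)cc1=O` is tested in a functional assay on HL-60 cells (Homo sapiens) for inhibition, read by sulforhodamine B assay, with a stated time of 48 h (a higher number here means a weaker inhibitor, a lower number a stronger inhibitor), where compound 1 gives > 50000 nM, which is a limit of the assay and not a number. Compound 2 `CC(C)CC(=O)NC(=O)c1c[nH]c([C@@H](O)c2ccccc2)cc1=O` carries isobutylcarbonyl in place of hydrogen on an amide-type nitrogen, and in this assay compound 2 gives > 50000 nM, again a limit. The step that the two limits leave unreadable from compound 1 to compound 2 is therefore unreadable, as the limit of > 50000 nM in this assay, at which 2 of the 2 values shown sit, shows. Compound 3 `NC(=O)c1cn(CCO)c([C@@H](O)c2ccccc2)cc1=O` carries 2-hydroxyethyl in place of hydrogen on an aromatic nitrogen. Among the compounds with values here, no measured step bears on this change, and no step beyond the scatter is expected. The estimate for compound 3 is 50000 nM, from 20000 nM to 100000 nM, which means an expected step of a number no higher from compound 1 to compound 3 (the limit leaves the size open).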

Compound 3, half-maximal inhibitory concentration: > 50000 nM
Compound 3: no number, only a limit; the forecaster's own chance of this, stated with the estimate: 70%; the middle value sits exactly at the limit.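

Compound 3 also gives only a limit of the assay and not a number, so no step from compound 1 to compound 3 can be read: the limit of > 50000 nM in this assay, at which 3 of the 3 values shown sit.

The compounds shown leave open whether any change to the core of compound 1 gives a readable potency in this assay.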